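Swapping the cyclopropyl for a methoxymethyl arm

This account rests on a few compounds, and the source may have more. Where it says the series, first, only, none or still open, it means among the compounds named here.

Measured so far:
- compound 1 `CC[C@H](C1CC1)n1c(=O)c(C)nc2c(-c3cc(F)c(OC)cc3Cl)ccnc21`: 1.7 nM
- compound 2 `CC[C@H](C1CC1)n1c(=O)c(C)nc2c(-c3cc(Cl)c(OC)cc3C)ccnc21`: 4.5 nM
- compound 3 `CC[C@@H](C1CC1)n1c(=O)c(C)nc2c(-c3ccc(Cl)cc3Cl)nccc21`: 55 nM

Of the compounds shown here, three built on the same fused core have been tested in a functional assay for antagonist activity at corticotropin-releasing factor receptor 1 (Rattus norvegicus); a higher number here means a weaker inhibitor, a lower number a stronger inhibitor. Compound 1 gives 1.7 nM in this assay and compound 2 gives 4.5 nM. Compound 3 stands apart: with 55 nM it is the weakest inhibitor of the three, and its distance to compound 2, as to compound 1, lies beyond the usual scatter of repeated measurements.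

Compound 4 `CC[C@H](COC)n1c(=O)c(C)nc2c(-c3ccc(Cl)cc3Cl)nccc21` keeps the core and the dichlorinated aryl group of compound 3 and changes only the branched chain on the aromatic nitrogen: 1-(methoxymethyl)propyl in place of 1-cyclopropylpropyl on an aromatic nitrogen. A ring of three carbons leaves, and a chain carrying an oxygen comes in, with the count of heavy atoms unchanged.

Within the data shown here, no pair among the measured compounds isolates this exchange, so its effect is not yet anchored by data. The closest guide is that compound 3 already sits at the weak end of the series. Without a measured precedent, a modest shift is expected, most likely toward a slightly higher number, but one that could well stay within scatter. Compound 4 is therefore expected to give about 80 nM in this assay, plausibly between 25 nM and 250 nM, which would mean an expected step of a 1.5-fold higher number from compound 3 to compound 4 (0.16 log units; within the scatter).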

Compound 4, half-maximal inhibitory concentration: 150 nM
Estimate against measurement, compound 4: 1.9-fold (0.27 log units) below, and the stated range covers the measured number.
By their numbers in this assay, from the lowest: compound 1; then compound 2; then compound 3; then compound 4.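

In this assay, among these compounds, replacing the ring with the oxygen-bearing chain gives a 2.7-fold higher number from compound 3 to compound 4 (0.44 log units; beyond the scatter), the first step here that isolates a single change at the branched group on the aromatic nitrogen. It shows that this position responds to the exchange, even though compound 3 already sits at the weak end of the set: 1-cyclopropylpropyl and 1-(methoxymethyl)propyl have the same heavy-atom count, so matching that count alone does not preserve the measured inhibition. The step cannot be assigned to a cause, as there is no supporting evidence on whether the loss of the ring, the entry of the oxygen or the added hydrogen-bond acceptor matters most.

A comparison with 1-ethylpropyl, an open chain of carbon only, would help separate the loss of the ring from the arrival of the oxygen, while 1-(ethoxymethyl)propyl would test a longer chain that keeps the oxygen. Going by these compounds, it also remains open whether the same exchange would give a step of similar size on the core and aryl groups of compound 1 or compound 2.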